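The source may hold more compounds than are shown below. What is called first, only, known or untested is meant among the compounds shown, and "the series" means these compounds.

Compound 1 `N#C/C(=C\c1c(-c2ccccc2)[nH]c2ccccc12)C(=O)c1ccccc1` and compound 2 `CCOC(=O)C(=Cc1c(-c2ccccc2)[nH]c2ccccc12)C(=O)OCC` share one core and differ in the group on the exocyclic double bond. In a functional assay on UO-31 cells (Homo sapiens) for inhibition, read by sulforhodamine B assay, with a stated time of 48 h (a lower number here means a stronger inhibitor of growth, a higher number a weaker inhibitor of growth), compound 1 gives 30500 nM, the higher of the two numbers, and compound 2 gives 4000 nM, a lower figure beyond the usual scatter. Compound 3 `N#C/C(=C\c1c(-c2ccccc2)[nH]c2ccccc12)S(=O)(=O)c1ccccc1` is still to be measured in this assay. It differs from compound 1 by phenylsulfonyl in place of benzoyl on a double-bonded chain carbon bound to a double-bonded chain carbon and a triple-bonded carbon. For the measured compounds named here, no measured pair shows this change, so only a small step with no clear direction is expected. Compound 3 is expected to give about 20000 nM, within 6000 nM to 60000 nM. The expected step is a 1.5-fold lower number from compound 1 to compound 3 (0.18 log units; within the scatter).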

Compound 3, concentration for 50% growth inhibition: 6700 nM
Beside the measured number, compound 3's estimate is 3.0-fold (0.47 log units) above it; the measured number falls inside the stated range.
By their numbers in this assay, from the lowest: compounds 2 and 3 (each within the scatter of the next); then compound 1.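

In this assay, phenylsulfonyl in place of benzoyl on a double-bonded chain carbon bound to a double-bonded chain carbon and a triple-bonded carbon gives a 4.6-fold lower number from compound 1 to compound 3 (0.66 log units; beyond the scatter). This single exchange shows that the number responds to the group at this position, which the earlier pair could not isolate. No measurement given here explains the step.

The compounds shown leave open how an amide or a carboxylic acid would behave at this position. They also leave open whether the step would persist with a methylsulfonyl group in place of phenylsulfonyl.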